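The compounds below may be only part of what the source reports. "The series", "measured", "known", "first", "only" and "open" are said of these compounds alone.

Measured compounds:
Compound 1 `O=C(CN(c1nc(Cl)nc2c1ncn2C1CCCCO1)C1CC1)NCC(=O)OCc1ccccc1` gives 25.9% in a functional assay on the whole organism with Mus musculus as the target, with a stated time of 90 min, at a dose of 25 umol/kg by the oral route; on this read-out lower numbers stand for a weaker effect and higher numbers for a stronger effect at the one dose given.
Compound 2 `CC(C)(C)OC(=O)NCCCC[C@H](NC(=O)CN(c1nc(Cl)nc2c1ncn2C1CCCCO1)C1CC1)C(=O)OCc1ccccc1` gives 32.9% in this assay.

Compound 2 stands with the higher of the two numbers recorded in this assay, but its gap to compound 1 is one the scatter would account for, so the two are not separated in effect. Within the data shown here, the single step between measured compounds is a number 7 percentage points higher from compound 1 to compound 2 (within the scatter), and it is the only step that bears on the present question.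

Compound 3 `C[C@@H](O)[C@H](NC(=O)CN(c1nc(Cl)nc2c1ncn2C1CCCCO1)C1CC1)C(=O)OCc1ccccc1` is the unmeasured partner of compound 2. The change is 1-hydroxyethyl in place of 4-((tert-butoxycarbonyl)amino)butyl on a saturated chain carbon bound to an amide-type nitrogen and a carbonyl carbon. Among the measured compounds shown here, the one relevant step shows that placing a large group on that saturated chain carbon, in place of hydrogen, did not move the read-out beyond the scatter. Compound 3 carries a much smaller group there, so no step beyond the scatter is expected in either direction, and the estimated step is a number 4.9 percentage points lower from compound 2 to compound 3 (within the scatter).

Compound 3 is therefore expected to give about 28% in this assay, with the estimate spanning from 14% to 42%.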

Compound 3, a percentage reported as activity, at one dose (the size of the read-out at that dose, not a potency): 23.4%
Estimate against measurement, compound 3: 4.6 percentage points above, within the range that was stated.
By their numbers in this assay, from the lowest: compounds 3, 1 and 2 (each within the scatter of the next).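

In this assay, the swap of 4-((tert-butoxycarbonyl)amino)butyl for 1-hydroxyethyl on a saturated chain carbon bound to an amide-type nitrogen and a carbonyl carbon gives a number 9.5 percentage points lower from compound 2 to compound 3 (within the scatter), and the swap of hydrogen for 1-hydroxyethyl at the same place gives a number 2.5 percentage points lower from compound 1 to compound 3 (within the scatter). Together with the earlier step, this shows that hydrogen, a group of 3 heavy atoms with a defined stereocentre and a group of 12 heavy atoms are not separated at this position, so neither the size of the group nor the change from the carbamate-bearing chain to the hydroxyl-bearing one has moved the read-out beyond the scatter. No separate measurement bears on this result.

The compounds shown leave open whether a free amine at the end of the butyl chain, a carboxylic acid or a longer chain on that saturated chain carbon would produce a step beyond the scatter in this assay. They also leave open whether 1-hydroxyethyl with the opposite stereocentre would read the same, and how the three compounds would compare at any other dose.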